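The compounds below may be only part of what the source reports. "The series", "measured", "known", "first", "only" and "open" are said of these compounds alone.

Measured compounds:
Compound 1, `CC(=O)c1cc(-c2ccc(F)cc2)cc2cc(-c3ccc(F)cc3)[nH]c12`: 90.1%
Compound 2, `COc1ccc(-c2cc(C(C)=O)c3[nH]c(-c4ccc(F)cc4)cc3c2)cc1`: 74.5%
Compound 3, `CC(=O)c1cc(/C=C/c2ccc(F)cc2)cc2cc(-c3ccc(F)cc3)[nH]c12`: 72.6%

These three were run in a functional assay on HeLa cells (Homo sapiens) for cytotoxicity, read by MTT assay, with a stated time of 2 days, tested at 0.1 uM; on this read-out lower numbers stand for a stronger effect and higher numbers for a weaker effect at the one concentration tested. From compound 1 to compound 2 the change is methoxy in place of fluoro on an aromatic carbon, and it gave a number 15.6 percentage points lower from compound 1 to compound 2 (beyond the scatter). Compound 3 carries a different core, differing from compound 1 by 2-(4-fluorophenyl)ethenyl in place of 4-fluorophenyl on an aromatic carbon, and the step was a number 17.5 percentage points lower from compound 1 to compound 3 (beyond the scatter). Compound 2 and compound 3 sit close, a number 1.9 percentage points lower from compound 2 to compound 3 (within the scatter).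

Compound 4, `COc1ccc(-c2cc3cc(/C=C/c4ccc(F)cc4)cc(C(C)=O)c3[nH]2)cc1`, is not yet measured. It differs from compound 3 by methoxy in place of fluoro on an aromatic carbon, the same change as that from compound 1 to compound 2, at a place described in the same words. For compound 4 in this assay an estimated step of a number 10.6 percentage points lower from compound 3 to compound 4 (beyond the scatter) is expected, resting on the earlier step of a number 15.6 percentage points lower from compound 1 to compound 2 (beyond the scatter), though with compound 3 already lower the step may be smaller. The estimate for compound 4 is 62%, between 48% and 76%.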

Compound 4, a percentage reported as activity, at one concentration (the size of the read-out at that concentration, not a potency): 90.5%
Compound 4: the middle estimate sits 28.5 percentage points below what was measured; measured number outside the range, above it.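

In this assay, methoxy in place of fluoro on an aromatic carbon gave a number 17.9 percentage points higher from compound 3 to compound 4 (beyond the scatter) and so did not carry over from one core to the other, as the two steps differ: the same change on two cores in this assay, a number 15.6 percentage points lower (beyond the scatter) from compound 1 to compound 2 and a number 17.9 percentage points higher (beyond the scatter) from compound 3 to compound 4, 33.5 percentage points apart, beyond the scatter of two such steps.

The result of going from 4-fluorophenyl to 4-methoxyphenyl therefore depended on the core in these compounds. It rests on a single pair per core at one concentration, and it does not show why the direction turned over or what a third core would do.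

The compounds shown leave open whether an amine or a carboxylic acid in place of methoxy would follow either step. They also leave open how a longer chain in place of 2-(4-fluorophenyl)ethenyl would behave.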